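Tert-Butyl for Methyl: an Expected Solubility Cost

A few compounds are considered here, and "the series" means these few. Any claim that something is new, unique, unknown or untested is made for them only; others in the source may bear on it.

Measured compounds:
compound 1 `Cc1cn2c(N3CC[C@H](N(C)C)C3)c(-c3ccccc3)c(C)c(C#N)c2n1` gives 356 ug/mL
compound 2 `Cc1c(-c2ccccc2)c(N2CC[C@H](N(C)C)C2)n2nc(C(C)(C)C)cc2c1C#N` gives < 2 ug/mL
compound 3 `CCN(CC)CCNc1c(-c2ccccc2)c(C)c(C#N)c2nc(C(C)(C)C)nn12` gives 2 ug/mL

In a physicochemical assay for solubility, at pH 6.8 (a lower number here means a less soluble compound, a higher number a more soluble compound), compound 1 holds the highest of the two numbers reported. The nearest number belongs to compound 3, which gives 2 ug/mL in this assay, a gap far beyond the scatter. For compound 2 the result is only a limit of the assay, (the limit of < 2 ug/mL in this assay, at which 1 of the 3 values shown sits), and not a number.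

Compound 4 `Cc1c(-c2ccccc2)c(N2CC[C@H](N(C)C)C2)n2cc(C(C)(C)C)nc2c1C#N` has not yet been measured. It differs from compound 1 in one place: tert-butyl in place of methyl on an aromatic carbon. Compounds 2 and 3 also carry a tert-butyl group, but each differs from compound 1 in more than that one place, so what their values show of the tert-butyl group itself is not separated here.

Compound 4 is expected to sit well below compound 1, with a step of an 18-fold lower number from compound 1 to compound 4 (1.25 log units; beyond the scatter) that goes beyond the scatter, because compound 3 with its tert-butyl gives 2 ug/mL. The estimate for compound 4 is 20 ug/mL, in a range from 3 ug/mL to 120 ug/mL.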

Compound 4, solubility: 27 ug/mL
Compound 4: the middle estimate sits 1.4-fold (0.13 log units) below what was measured, within the range that was stated.
By their numbers in this assay, from the lowest: compound 3; then compound 4; then compound 1.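

With compound 4, the change of methyl to tert-butyl on an aromatic carbon of the five-membered ring can be read on its own in this assay, and it gives a 13-fold lower number from compound 1 to compound 4 (1.12 log units; beyond the scatter). Among these compounds, compounds 2 and 3 also carry tert-butyl but differ from compound 1 in more than one place, so this pair is the first to tie a step of this size to this single change at this position, with the rest of the core of compound 1 left as it is. Nothing shown here gives a cause for the step.

On these data alone, whether an ethyl group, an amine or a carboxylic acid on this same carbon would give a number nearer to compound 1 or to compound 4 stays open. As far as these compounds go, how large the same change would be on the cores of compound 2 and compound 3 also stays open.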